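Swapping Methoxy for Chloro on a Second Core

The source may hold more compounds than are shown below. What is called first, only, known or untested is meant among the compounds shown, and "the series" means these compounds.

Compound 2 `C=C(Br)C(=O)Nc1cccc(-c2cn3c(-c4ccc(OC)cc4)csc3n2)c1` and compound 1 `C=C(Br)C(=O)Nc1cccc(-c2cn3c(-c4ccc(Cl)cc4)csc3n2)c1` share one core and differ in a single group. In a functional assay on CCRF-CEM cells (Homo sapiens) for inhibition, read by cell counting, with a stated time of 3 days (a higher number here means a weaker inhibitor, a lower number a stronger inhibitor), compound 2 gives 500 nM, while compound 1 gives 2200 nM. The change chloro in place of methoxy on an aromatic carbon thus made a step of a 4.4-fold higher number from compound 2 to compound 1 (0.64 log units; beyond the scatter).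

Compound 3 `C=C(Br)C(=O)Nc1cccc(-c2cn3nc(-c4ccc(OC)cc4)sc3n2)c1` keeps the same 4-methoxyphenyl group but sits on a second core; the difference between the two cores is not broken down here. In this assay compound 3 gives 1200 nM.

Compound 4 `C=C(Br)C(=O)Nc1cccc(-c2cn3nc(-c4ccc(Cl)cc4)sc3n2)c1` is not yet measured. It repeats on the core of compound 3 the change already seen: chloro in place of methoxy on an aromatic carbon. The place is the same in both cases, so this is the same change made on a second core.

Compound 4 is expected to give 3800 nM in this assay, with a likely range from 1500 nM to 9500 nM. That estimate means an expected step of a 3.2-fold higher number from compound 3 to compound 4 (0.50 log units; beyond the scatter), judged to be about as large as the earlier one because the same change gave a 4.4-fold higher number from compound 2 to compound 1 (0.64 log units; beyond the scatter). Whether the second core carries the change through in the same way is the open question.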

Compound 4, half-maximal inhibitory concentration: 3200 nM
Beside the measured number, compound 4's estimate is 1.2-fold (0.07 log units) above it; measured number inside the range.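

On the second core, putting chloro in place of methoxy again gave a weaker inhibitor in this assay, with a 2.7-fold higher number from compound 3 to compound 4 (0.43 log units; beyond the scatter). Set beside the earlier step, the change points the same way on both cores, and the sizes of the two steps cannot be told apart: the same change on two cores in this assay, a 4.4-fold higher number (0.64 log units; beyond the scatter) from compound 2 to compound 1 and a 2.7-fold higher number (0.43 log units; beyond the scatter) from compound 3 to compound 4, 1.7-fold (0.22 log units) apart, within the scatter of two such steps. This shows that within these two pairs the change carried from one core to the other with much the same result, but two pairs do not make a general rule, and they do not explain why chloro gives the weaker inhibitor here or predict the step on any further core.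

The compounds shown compare only methoxy and chloro at this place on the ring, so the effect of a fluoro, a methyl or an amine there remains open on either core. Also open, on these data alone, is whether the same step would appear with a hydrogen in place of the bromine that all four compounds carry.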